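Aryl variation on the sulfonamide nitrogen; step to compound 4

The source may report more compounds than this note shows. Statements on the series, on what has been measured and on what is new or still open speak of the compounds shown alone.

Of the compounds shown here, three on a shared core have been measured in a functional assay on cells (leukaemia cell line, Homo sapiens) for inhibition, read by sulforhodamine B assay, with a stated time of 48 h; on this read-out lower numbers stand for stronger inhibition of growth and higher numbers for weaker inhibition of growth. Compound 1 `O=S(=O)(Nc1ccc(Cl)cc1Cl)c1ccc(-c2cnc(C3CC3)o2)cc1` gives 481 nM, compound 2 `O=S(=O)(Nc1ccccc1Cl)c1ccc(-c2cnc(C3CC3)o2)cc1` gives 429 nM, and compound 3 `O=S(=O)(Nc1ccc(F)c(Cl)c1)c1ccc(-c2cnc(C3CC3)o2)cc1` gives 260 nM. All three differ only in the aryl group on the sulfonamide nitrogen. The steps are small: a 1.1-fold lower number from compound 1 to compound 2 (0.05 log units; within the scatter), a 1.9-fold lower number from compound 1 to compound 3 (0.27 log units; within the scatter), and a 1.7-fold lower number from compound 2 to compound 3 (0.22 log units; within the scatter). Compound 3 has the lowest of the three numbers in this assay, but both steps that reach it lie within the scatter, so no ranking among compounds 1, 2 and 3 is supported.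

Compound 4 `Cc1cc(NS(=O)(=O)c2ccc(-c3cnc(C4CC4)o3)cc2)ccc1Cl` continues this variation: 4-chloro-3-methylphenyl in place of 3-chloro-4-fluorophenyl on a sulfonamide nitrogen. The three measured steps all bear on it, since each also exchanges one aryl group for another at the same nitrogen, and none of them moved the number beyond the scatter. No step beyond the scatter is therefore expected in this assay for the change from compound 3 to compound 4, that is a 1.2-fold higher number from compound 3 to compound 4 (0.09 log units; within the scatter). Compound 4 is expected to give about 320 nM in this assay, with a range from 150 nM to 700 nM.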

Compound 4, concentration for 50% growth inhibition: 216 nM
Compound 4: the middle estimate sits 1.5-fold (0.17 log units) above what was measured, within the range that was stated.
By their numbers in this assay, from the lowest: compounds 4, 3, 2 and 1 (each within the scatter of the next, the first and the last beyond it).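

In this assay, the change from 3-chloro-4-fluorophenyl to 4-chloro-3-methylphenyl gives a 1.2-fold lower number from compound 3 to compound 4 (0.08 log units; within the scatter), so this position on the sulfonamide nitrogen accepts a methyl-bearing aryl group as well as the dihalogenated one. The comparison with 2-chlorophenyl gives a 2.0-fold lower number from compound 2 to compound 4 (0.30 log units; within the scatter), whereas the comparison with 2,4-dichlorophenyl gives a 2.2-fold lower number from compound 1 to compound 4 (0.35 log units; beyond the scatter), the first modest separation between two aryl groups at this nitrogen. No measurement shown accounts for that separation.

From the compounds shown here alone, whether an aryl group bearing an amine or a carboxylic acid, or a longer alkyl chain in place of the aryl group, keeps growth inhibition in this assay remains open. Going by these compounds, it is also open whether the separation seen here holds on a different core.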